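From Amide to Urea: What Compound 4 Might Give

The compounds below may be only part of what the source reports. "The series", "measured", "known", "first", "only" and "open" are said of these compounds alone.

In a functional assay on SK-MEL-28 cells (Homo sapiens) for inhibition, read by sulforhodamine B assay, with a stated time of 48 h (on this read-out higher numbers stand for weaker inhibition of growth and lower numbers for stronger inhibition of growth), compound 3 `COc1cc(-c2nn(-c3cccc(NC(=O)c4cccc(C(F)(F)F)c4)c3)cc2-c2ccncc2)ccc1Cl` gives 2490 nM, the second highest of the three numbers measured. Compound 1 `O=C(Nc1cccc(-n2cc(-c3ccncc3)c(-c3ccc(Cl)c(O)c3)n2)c1)Nc1cccc(C(F)(F)F)c1` gives 4110 nM, which lies within the scatter of the number for compound 3. Compound 2 `COc1cc(-c2nn(-c3cccc(NC(=O)Nc4cc(C(F)(F)F)cc(C(F)(F)F)c4)c3)cc2-c2ccncc2)ccc1Cl` gives 851 nM, a gap beyond the scatter on the stronger side. Compound 4 `COc1cc(-c2nn(-c3cccc(NC(=O)Nc4ccc(Cl)c(Cl)c4)c3)cc2-c2ccncc2)ccc1Cl` is not yet measured. It differs from compound 3 by (3,4-dichlorophenyl)amino in place of 3-(trifluoromethyl)phenyl on a carbonyl carbon, so the amide becomes a urea. Within the data shown here, no measured pair shows this exact change. Compound 2 also carries a urea and gives 851 nM. On that basis a modest step toward stronger growth inhibition is expected, a 1.7-fold lower number from compound 3 to compound 4 (0.22 log units; within the scatter). Compound 4 is therefore estimated at 1500 nM, with a range from 500 nM to 5000 nM.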

Compound 4, concentration for 50% growth inhibition: 1430 nM
Compound 4: the middle estimate sits 1.0-fold (0.02 log units) above what was measured, within the range that was stated.
By their numbers in this assay, from the lowest: compounds 2, 4, 3 and 1 (each within the scatter of the next, the first and the last beyond it).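

On the carbonyl carbon, exchanging 3-(trifluoromethyl)phenyl for (3,4-dichlorophenyl)amino turns the amide into a urea, and in this assay this gives a 1.7-fold lower number from compound 3 to compound 4 (0.24 log units; within the scatter) for the change. This position therefore accepts both the amide and this urea, with no clear effect on growth inhibition. Compound 4 changes the linking group and the ring substituents together, and their separate contributions cannot be told apart. As far as these compounds go, whether an amine or a carboxylic acid on that ring would be accepted also stays open. No evidence here explains the result.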